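From Ethoxy to Ethylsulfanyl on a Thiocarbonyl Carbon

This account rests on a few compounds, and the source may have more. Where it says the series, first, only, none or still open, it means among the compounds named here.

Compound 1 `CCSC(=S)SCC(=O)c1ccc(S(=O)(=O)Nc2ccc(OC)cc2)cc1`: 4320 nM
Compound 2 `CCSC(=S)SCC(=O)c1cccc(NC(C)=O)c1`: 9380 nM
Compound 3 `CCOC(=S)SCC(=O)c1ccc(OC)cc1`: 4640 nM

These three compounds were tested in a functional assay on HeLa cells (Homo sapiens) for cytotoxicity, read by resazurin assay, with a stated time of 72 h; on this read-out higher numbers stand for weaker inhibition and lower numbers for stronger inhibition. Compound 3 stands second highest of the three numbers; compound 1 is its nearest neighbour, with a gap within the usual scatter, and compound 2 is furthest, with a gap beyond it.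

Compound 4 `CCSC(=S)SCC(=O)c1ccc(OC)cc1` is not yet measured. It differs from compound 3 in one place: ethylsulfanyl in place of ethoxy on a thiocarbonyl carbon. For the measured compounds named here, no measured pair shows this same change, so its effect is unknown here. Compound 1, which already carries ethylsulfanyl at this place, gives 4320 nM in this assay, close to compound 3. The step from compound 3 to compound 4 is therefore expected to be small, with no clear direction, as a 1.0-fold lower number from compound 3 to compound 4 (0.00 log units; within the scatter). Compound 4 is estimated at 4600 nM, between 2000 nM and 10500 nM.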

Compound 4, half-maximal inhibitory concentration: 1960 nM
Estimate against measurement, compound 4: 2.3-fold (0.37 log units) above; the whole stated range lies above it.
By their numbers in this assay, from the lowest: compound 4; then compounds 1 and 3 (each within the scatter of the next); then compound 2.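

In this assay, for the compounds shown here, replacing ethoxy with ethylsulfanyl on a thiocarbonyl carbon gives a 2.4-fold lower number from compound 3 to compound 4 (0.37 log units; beyond the scatter) and is the first measured step at this position. The earlier compounds shown here could not show that exchanging one oxygen for one sulfur here, with the heavy-atom count unchanged, can move the number beyond the usual scatter. No measurement shown here explains this step. As far as these compounds go, it remains open whether a longer chain or an amine at this place would lower the number further, and whether the same exchange would have a similar effect on the core of compound 2.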